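Changing the aryl group on the carbamate of compound 1

This account rests on a few compounds, and the source may have more. Where it says the series, first, only, none or still open, it means among the compounds named here.

Measured compounds in a functional assay on RAW264.7 cells (Mus musculus) for inhibition, read by MTT assay, with a stated time of 72 h; on this read-out lower numbers stand for stronger inhibition and higher numbers for weaker inhibition:
- compound 1 `CCc1nc2c(C)cc(-c3ccc(CN4CCN(C)CC4)cc3)cn2c1NC(=O)OCc1cc(Cl)cc(Cl)c1`: 1410 nM
- compound 2 `CCc1nc2c(C)cc(-c3ccc(CN4CCC(C)CC4)cc3)cn2c1NC(=O)OCc1cc(Cl)cc(Cl)c1`: 2130 nM
- compound 3 `CCc1nc2c(C)cc(-c3ccc(CNCCO)cc3)cn2c1NC(=O)OCc1cc(Cl)cc(Cl)c1`: "nd" (no result reported)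

Compound 1 gives 1410 nM and compound 2 gives 2130 nM, two numbers within the scatter of each other. Within the data shown here, compound 3 has no number to set beside them, so compound 1 stands level with the only other compound that has a number in this assay.

The unmeasured compound 4 `CCc1nc2c(C)cc(-c3ccc(CN4CCN(C)CC4)cc3)cn2c1NC(=O)OCc1ccc(C(F)(F)F)cc1` keeps the shared core and the 4-methylpiperazin-1-yl group of compound 1 and changes one group: 4-(trifluoromethyl)phenyl in place of 3,5-dichlorophenyl on a saturated chain carbon bound to an oxygen next to a carbonyl group. In words, 4-(trifluoromethyl)phenyl takes the place of 3,5-dichlorophenyl on a saturated chain carbon bound to an oxygen next to a carbonyl group.

Among the measured compounds shown here, the only measured step, a 1.5-fold higher number from compound 1 to compound 2 (0.18 log units; within the scatter), exchanges 4-methylpiperazin-1-yl for 4-methylpiperidin-1-yl and lies within the scatter. It does not touch the group that changes here. Every measured compound carries 3,5-dichlorophenyl at this place, so the data show neither the size nor the direction of the change. No step beyond the scatter is therefore expected in this assay, but this is a default rather than a finding, and the range stays wide.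

The estimated step is a 1.3-fold higher number from compound 1 to compound 4 (0.11 log units; within the scatter).

For compound 4 the estimated value is 1800 nM, with an expected range from 600 nM to 5500 nM.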

Compound 4, half-maximal inhibitory concentration: > 20000 nM
Compound 4: no number, only a limit (the forecaster's own chance of this, stated with the estimate: 10%); at least 11-fold (1.04 log units) between middle value and limit.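

In this assay, the group on the saturated chain carbon bound to an oxygen next to a carbonyl group proves far less forgiving than the amine end of the molecule: 4-(trifluoromethyl)phenyl in place of 3,5-dichlorophenyl gives an at least 14-fold higher number from compound 1 to compound 4 (1.15 log units; beyond the scatter), whereas 4-methylpiperidin-1-yl in place of 4-methylpiperazin-1-yl gave only a 1.5-fold higher number from compound 1 to compound 2 (0.18 log units; within the scatter). The reading for compound 4 is a limit of the assay and not a number: the limit of > 20000 nM in this assay, at which 1 of the 4 values shown sits. Going by these compounds, this one exchange, with the shared core and the 4-methylpiperazin-1-yl group kept, is therefore enough to move the compound out of the measurable range, and the true size of the step stays unknown.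

The compounds shown leave open whether the loss follows from giving up the two chlorine atoms or from bringing in the trifluoromethyl group, as both changes come together in this single step. They also do not show how a 4-chlorophenyl or a 3,5-bis(trifluoromethyl)phenyl group would read at this place, or whether the same exchange would have a similar effect alongside the 4-methylpiperidin-1-yl group of compound 2.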